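Benzyl hydroxamic acid series: para substituent swap

The compounds below may be only part of what the source reports. "The series", "measured", "known", "first", "only" and "open" are said of these compounds alone.

Compound 1 `Cc1ccccc1CN1CC=C(CCC(=O)NO)C1=O` and compound 2 `Cc1ccc(CN2CC=C(CCC(=O)NO)C2=O)cc1` share the same core and differ only in where the methyl sits on the benzyl ring. In a functional assay on ACHN cells (Homo sapiens) for inhibition, read by sulforhodamine B assay (on this read-out lower numbers stand for stronger inhibition of growth and higher numbers for weaker inhibition of growth), compound 1 gives 3330 nM and compound 2 gives 3330 nM; the two values stand level at the digits shown, within the scatter of the assay, so no order between them can be drawn. No step beyond the scatter is recorded among the measured compounds.

Compound 3 `O=C(CCC1=CCN(Cc2ccc(F)cc2)C1=O)NO` has not yet been measured in this assay. It differs from compound 2 by fluoro in place of methyl on an aromatic carbon. The change exchanges one group of a single heavy atom for another of a single heavy atom, with no change in ring count, donors, acceptors or charge. With compound 1 at 3330 nM and compound 2 at 3330 nM standing level, nothing in the measured data points to a step in either direction, so the step from compound 2 to compound 3 is expected to lie within the scatter, a 1.1-fold higher number from compound 2 to compound 3 (0.02 log units; within the scatter). Compound 3 is therefore estimated at 3500 nM in this assay, with a range of 1500 nM to 8000 nM.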

Compound 3, concentration for 50% growth inhibition: 5990 nM
The estimate for compound 3 lay 1.7-fold (0.23 log units) below the measured number; the range from low to high includes it.
By their numbers in this assay, from the lowest: compounds 1, 2 and 3 (each within the scatter of the next).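

In this assay fluoro in place of methyl on an aromatic carbon, para to a large group, gives a 1.8-fold higher number from compound 2 to compound 3 (0.25 log units; within the scatter) and so adds a second kind of change to the series: compound 1 and compound 2 differ only in where the methyl sits, whereas compound 2 and compound 3 differ in which group occupies the same place. Exchanging one single-heavy-atom group for another at this position therefore stays within the scatter, and no step among these three compounds lies beyond it, although this reading covers only methyl and fluoro. Nothing at hand bears on the reason for the number seen with compound 3.

Still open, as far as these compounds go, is whether a larger group at this place, such as methoxy, an amine or a phenyl ring, would move the number beyond the scatter. Also open, from the compounds shown here alone, is whether changes away from the benzyl ring, such as a longer chain carrying the hydroxamic acid or a carboxylic acid in place of the hydroxamic acid, would produce a step that can be read.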